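The source may hold more compounds than are shown below. What is called first, only, known or untested is meant among the compounds shown, and "the series" means these compounds.

Measured so far:
- compound 1, `CC(C)OC(=O)N1CCC(Oc2ncnc3c2CCN3c2ccc(S(C)(=O)=O)cc2F)CC1`: 50.1 nM
- compound 2, `CSc1ccc(N2CCc3c(OC4CCN(C(=O)OC(C)C)CC4)ncnc32)cc1F`: 398 nM

In a functional assay on CHO-K1 cells for agonist activity at Glucose-dependent insulinotropic receptor (Homo sapiens), read by a luciferase reporter, with a stated time of 5 h (a higher number here means that more compound is needed for the effect, a lower number that less compound is needed), compound 2 gives the highest number of the two, and compound 1 gives the lower one. Compound 3, `CC(C)OC(=O)N1CCC(Oc2ncnc3c2CCN3c2ccc([S@@+](C)[O-])c(F)c2)CC1`, has not yet been measured; it differs from compound 2 by a group of 3 heavy atoms (1 carbon, 1 oxygen, 1 sulfur; no ring) in place of a group of 2 heavy atoms (1 carbon, 1 sulfur; no ring), on an aromatic carbon, ortho to a fluoro group. Within the data shown here, the only step that bears on this change is a 7.9-fold higher number from compound 1 to compound 2 (0.90 log units; beyond the scatter), where a methylsulfonyl group gave the lower number. The new group lies between those two in its make-up, so a lower number than compound 2 is expected for compound 3, of about a 3.1-fold lower number from compound 2 to compound 3 (0.49 log units; beyond the scatter). The estimate for compound 3 in this assay is 130 nM, with a range from 50 nM to 400 nM.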

Compound 3, half-maximal effective concentration: 631 nM
The estimate for compound 3 lay 4.9-fold (0.69 log units) below the measured number; measured number outside the range, above it.
By their numbers in this assay, from the lowest: compound 1; then compounds 2 and 3 (each within the scatter of the next).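

Putting one oxygen on the sulfur of methylsulfanyl gives a 1.6-fold higher number from compound 2 to compound 3 (0.20 log units; within the scatter), so at this place the new group cannot be told apart from methylsulfanyl. The methylsulfonyl group of compound 1 alone stands apart, with a 13-fold higher number from compound 1 to compound 3 (1.10 log units; beyond the scatter), so the number does not drop stepwise as oxygens are added to the sulfur. No measurement shown gives a reason for this.

Still open, as far as these compounds go, is how the mirror-image form of compound 3 would read, and whether an amine or a carboxylic acid at this place would come close to compound 1.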